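Swapping Trifluoromethyl for Chloro Starting from Compound 2

The source may hold more compounds than are shown below. What is called first, only, known or untested is meant among the compounds shown, and "the series" means these compounds.

Compound 2 `O=C(Nc1cccc(-n2cc(-c3ccncc3)c(-c3cc(O)cc(Cl)c3)n2)c1)Nc1ccc(Cl)c(C(F)(F)F)c1` holds the lowest of the two numbers measured in a functional assay on HCT-116 cells (Homo sapiens) for inhibition, read by sulforhodamine B assay, with a stated time of 48 h, tested at 10 uM; a higher number here means a weaker effect of the compound at the concentration tested, a lower number a stronger effect: in it, compound 2 gives 6.95%. Among the compounds with values here, the only other measured compound, compound 1 `COc1cc(Cl)cc(-c2nn(-c3cccc(NC(=O)c4ccc(Cl)c(Cl)c4)c3)cc2-c2ccncc2)c1`, gives 44.1% in this assay, a number well beyond the scatter above that of compound 2; since the two differ in more than one place, nothing more is said of that pair.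

Compound 3 `O=C(Nc1cccc(-n2cc(-c3ccncc3)c(-c3cc(O)cc(Cl)c3)n2)c1)Nc1ccc(Cl)c(Cl)c1` differs from compound 2 in one place: chloro in place of trifluoromethyl on an aromatic carbon. Within the data shown here, no measured pair in this set shows the effect of such an exchange, so the expectation rests on the value of compound 2 alone. The step from compound 2 to compound 3 in this assay is expected to be small, a number 3.1 percentage points higher from compound 2 to compound 3 (within the scatter), not beyond the scatter in either direction. Compound 3 is therefore estimated at 10%, with a range from 2% to 30%.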

Compound 3, a percentage reported as activity, at one concentration (the size of the read-out at that concentration, not a potency): -57.3%
Compound 3: the middle estimate sits 67.3 percentage points above what was measured; the whole stated range lies above it.
By their numbers in this assay, from the lowest: compound 3; then compound 2; then compound 1.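

In this assay the exchange of trifluoromethyl for chloro on this aromatic carbon, ortho to a chloro group, gives a large change: the number falls a number 64.3 percentage points lower from compound 2 to compound 3 (beyond the scatter) and is thus well beyond the scatter. This position is therefore not indifferent to its group, and going from 4-chloro-3-(trifluoromethyl)phenyl to 3,4-dichlorophenyl gives a much stronger effect at the concentration tested, with compound 3 reading -57.3% in this assay as a number below zero. Nothing measured here bears on the reason for a step of this size.

From the compounds shown here alone, whether a bromo, methyl or nitrile group on this carbon would read like chloro or like trifluoromethyl remains open. Also open, going by these compounds, is whether the same exchange would give a step of similar size in compound 1, which carries a different linking group and a methoxy group.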